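A few compounds are considered here, and "the series" means these few. Any claim that something is new, unique, unknown or untested is made for them only; others in the source may bear on it.

Measured compounds:
- compound 1, `CCC(=O)Oc1c(OC)c(OC)c(OC(=O)CC)c2cc(Cl)ccc12`: in a physicochemical assay for lipophilicity (a higher number here means a more lipophilic compound, a lower number a more polar compound), compound 1 gives 4.3
- compound 2, `COc1c(OC)c(OC(=O)C(C)(C)C)c2cc(Cl)ccc2c1OC(=O)C(C)(C)C`: compound 2 gives 6.6
- compound 3, `CCC(=O)Oc1c(OC)c(OC)c(OC(=O)CC)c2cc(OC)ccc12`: compound 3 gives 3.28

Compound 1 and compound 3 share one core and differ in a single place: methoxy in place of chloro on an aromatic carbon. That change produced a number 1.02 log units lower from compound 1 to compound 3 (beyond the scatter), a step that lies beyond the scatter.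

Compound 2 has the highest number of the three. Its nearest neighbour is compound 1, and its furthest is compound 3; both gaps are beyond the scatter. Compound 2 and compound 1 differ in more than one place, and the difference between the two cores is not broken down here.

Compound 4, `COc1ccc2c(OC(=O)C(C)(C)C)c(OC)c(OC)c(OC(=O)C(C)(C)C)c2c1`, is not yet measured. It differs from compound 2 in exactly one place: methoxy in place of chloro on an aromatic carbon. Going by the values given here, the place description matches, word for word, the one between compound 1 and compound 3, so this is the same change made on a second core. The change has been seen only once among the measured compounds, so the expectation rests on that single pair; whether the second core answers in the same way cannot be checked from the data at hand.

On that basis the step from compound 2 to compound 4 in this assay is expected to be a number 1.00 log units lower from compound 2 to compound 4 (beyond the scatter), set beside the measured a number 1.02 log units lower from compound 1 to compound 3 (beyond the scatter). Among the compounds with values here, compound 4 is therefore estimated at 5.6, with the likely range from 5.1 to 6.1, because the starting point of compound 2 is 6.6 and the one measured step of this change is a number 1.02 log units lower from compound 1 to compound 3 (beyond the scatter).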

Compound 4, partition coefficient: 5.4
Beside the measured number, compound 4's estimate is 0.20 log units above it; low and high end bracket the measured number.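

In this assay, methoxy in place of chloro on an aromatic carbon gives a number 1.20 log units lower from compound 2 to compound 4 (beyond the scatter), and the same change on the other core gives a number 1.02 log units lower from compound 1 to compound 3 (beyond the scatter), so both steps run in the same direction and both are large. Across these two pairs the change therefore carries from one core to the other in direction and in broad size, with the step on one core serving as a fair guide to the step on the other. Two pairs do not make a rule for the whole series, however, and they do not show whether a further core would answer in the same way; nothing at hand bears on why the step takes this direction or this size.

The compounds shown leave open how other groups on the same aromatic carbon would compare with chloro and methoxy on either core, for example an amine, a carboxylic acid or a longer chain such as butoxy. They also leave open whether the step would keep its direction and size with an amine or a carboxylic acid elsewhere on the shared core.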